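Methoxy for isopropyl on the aryl urea of compound 2

A few compounds are considered here, and "the series" means these few. Any claim that something is new, unique, unknown or untested is made for them only; others in the source may bear on it.

Compound 1 `CC(C)c1cccc(NC(=O)N[C@H](C)c2ccccc2)c1` and compound 2 `CC(C)c1cccc(NC(=O)N[C@@H](C)c2ccccc2)c1` share all atoms and bonds and differ only in configuration. In an ADME assay on the whole organism with Oryza sativa as the target, tested at 0.1 uM (a higher number here means a weaker effect of the compound at the concentration tested, a lower number a stronger effect), compound 1 gives 74%, while compound 2 gives 95%; the step of a number 21 percentage points higher from compound 1 to compound 2 (beyond the scatter) rests on (the fact that compounds 1 and 2 differ only in the configuration as drawn). Compound 3 `CCCCCc1ccc(NC(=O)N[C@@H](C)c2ccccc2)cc1` gives 98% in this assay, so compound 2 stands second highest of the three, with compound 3 within the scatter and compound 1 well below. Compound 4 `COc1cccc(NC(=O)N[C@@H](C)c2ccccc2)c1` brings (methoxy in place of isopropyl on an aromatic carbon). Within the data shown here, no measured step touches this change; the values of compound 2 and compound 3 merely show that two aryl substituents give like numbers. The step of a number 3 percentage points lower from compound 2 to compound 4 (within the scatter) is therefore expected to stay within the scatter. Compound 4 is estimated at 92%, between 74% and 100%.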

Compound 4, a percentage reported as activity, at one concentration (the size of the read-out at that concentration, not a potency): 101%
Beside the measured number, compound 4's estimate is 9 percentage points below it; measured number outside the range, above it.
By their numbers in this assay, from the lowest: compound 1; then compounds 2, 3 and 4 (each within the scatter of the next).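

In this assay, methoxy in place of isopropyl gives a number 6 percentage points higher from compound 2 to compound 4 (within the scatter), so on this aromatic carbon the exchange, with the hydrogen-bond acceptor it brings, does not separate the two compounds. With the configuration held as drawn in compound 2, this step isolates a change of aryl substituent, where the earlier step isolated only a change of configuration. Nothing available explains why the two numbers stay level.

Open, from the compounds shown here alone, is whether an amine or a carboxylic acid at this position would also stay level with compound 4. Also open, going by these compounds, is whether methoxy would behave alike in the configuration of compound 1, which gives 74%.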